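Bromo in place of chloro on compound 2

The source may hold more compounds than are shown below. What is called first, only, known or untested is meant among the compounds shown, and "the series" means these compounds.

Compound 1 `COc1ccccc1Oc1c(N)nc(-c2ccc(Br)cc2)nc1Cl` - 4440 nM
Compound 2 `COc1ccccc1Oc1c(N)nc(-c2ccc(Cl)cc2)nc1OCCO` - 7740 nM

Both compounds were tested in a functional assay on B16 cells (Mus musculus) for cytotoxicity, read by CCK-8 assay, with a stated time of 24 h; a higher number here means a weaker inhibitor, a lower number a stronger inhibitor. There compound 2, at 7740 nM, lies within the usual scatter of compound 1, at 4440 nM. The two differ in more than one place, so their values isolate no single change.

Compound 3 `COc1ccccc1Oc1c(N)nc(-c2ccc(Br)cc2)nc1OCCO` has not yet been measured. It differs from compound 2 by bromo in place of chloro on an aromatic carbon, with bromo in place of chloro on an aromatic carbon, para to a large group. For the measured compounds named here, no measured pair shows this change alone, so the expectation in this assay is no step beyond the scatter, in neither direction. The estimated step of a 1.1-fold lower number from compound 2 to compound 3 (0.04 log units; within the scatter) is expected to stay within that scatter. For compound 3 the estimated value is 7000 nM, with an expected range from 3500 nM to 14000 nM.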

Compound 3, half-maximal inhibitory concentration: 11800 nM
Beside the measured number, compound 3's estimate is 1.7-fold (0.23 log units) below it; low and high end bracket the measured number.
By their numbers in this assay, from the lowest: compounds 1, 2 and 3 (each within the scatter of the next, the first and the last beyond it).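

In this assay, the change from 4-chlorophenyl to 4-bromophenyl gives a 1.5-fold higher number from compound 2 to compound 3 (0.18 log units; within the scatter) and so does not separate the two halogens at this position while 2-hydroxyethoxy is present. For the compounds shown here, with 4-bromophenyl held constant, 2-hydroxyethoxy in place of the chloro on the other aromatic carbon gives a 2.7-fold higher number from compound 1 to compound 3 (0.42 log units; beyond the scatter) and is thus a modest step, the only single change here that passes the scatter. No measurement shown accounts for either step. From the compounds shown here alone, whether an amine or a methoxy group in place of the bromo would move the number beyond the scatter remains open. So does the outcome of a longer chain or a carboxylic acid in place of the 2-hydroxyethoxy group.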